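Dropping a phenyl from compound 1: what to expect

This account rests on a few compounds, and the source may have more. Where it says the series, first, only, none or still open, it means among the compounds named here.

Measured so far:
compound 1 `Nc1ccccc1NC(=O)c1ccc(CSC(=S)N2CCN(C(c3ccccc3)c3ccccc3)CC2)cc1` — 13.8%
compound 2 `Nc1ccccc1NC(=O)c1ccc(CSC(=S)N2CCc3cc([N+](=O)[O-])ccc32)cc1` — 43.6%

In a functional assay on HeLa cells (Homo sapiens) for antiproliferative activity, read by CCK-8 assay, with a stated time of 72 h, tested at 8 uM (a higher number here means a stronger effect of the compound at the concentration tested, a lower number a weaker effect), compound 1 gives 13.8%, the lowest of the two numbers here; compound 2 gives 43.6%, a higher reading that lies beyond the usual scatter. Compound 3 `Nc1ccccc1NC(=O)c1ccc(CSC(=S)N2CCN(Cc3ccccc3)CC2)cc1` is not yet measured. It differs from compound 1 in one place: hydrogen in place of phenyl on a saturated chain carbon bound to an amine nitrogen in a ring and an aromatic carbon. Among the measured compounds shown here, no measured pair shows this change, so nothing here tells how large its effect is. Compound 3 is expected to land close to compound 1, with a number 4.2 percentage points higher from compound 1 to compound 3 (within the scatter) a step expected to stay within the scatter. Compound 3 is thus estimated at 18%, in the range 5% to 35%.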

Compound 3, a percentage reported as inhibition, at one concentration (the size of the read-out at that concentration, not a potency): 31.3%
Compound 3: the middle estimate sits 13.3 percentage points below what was measured; low and high end bracket the measured number.
By their numbers in this assay, from the lowest: compound 1; then compound 3; then compound 2.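

In this assay, hydrogen in place of phenyl on this saturated chain carbon gives a number 17.5 percentage points higher from compound 1 to compound 3 (beyond the scatter) and so shows that this position responds to the change. Compound 3 keeps one phenyl on that carbon, and losing the other does not lower the reading. Nothing measured here explains why the reading rises.

Still open, going by these compounds, is whether the remaining phenyl contributes to the reading at all. On these data alone, the effect of a methyl group, a longer chain or an amine on this carbon also remains unknown.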